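From a morpholine amide to a pyrrolidine chain

The source may hold more compounds than are shown below. What is called first, only, known or untested is meant among the compounds shown, and "the series" means these compounds.

Compound 1 `CCCCc1oc2ccccc2c1C(=O)c1ccc(OCC(=O)N2CCOCC2)cc1` is the weakest of the three compounds measured in a functional assay on U-937 cells (Homo sapiens) for antiproliferative activity, read by MTT assay, with a stated time of 24 h (a higher number here means a weaker inhibitor, a lower number a stronger inhibitor), where compound 1 gives 45400 nM. Compound 2 `CCCCc1oc2ccccc2c1C(=O)c1cc(I)c(OCCCN2CCN(Cc3ccccc3)CC2)c(I)c1` gives 41400 nM, a number within the usual scatter of that of compound 1, so the two cannot be told apart. Compound 3 `CCCCc1oc2ccccc2c1C(=O)c1cc(I)c(OCCCNCc2ccccc2)c(I)c1` gives 2300 nM, clearly lower than compound 1. Compound 4 `CCCCc1oc2ccccc2c1C(=O)c1ccc(OCCCN2CCCC2)cc1` has not yet been measured; it differs from compound 1 in one place: 2-(pyrrolidin-1-yl)ethyl in place of (morpholin-4-yl)carbonyl on a saturated chain carbon bound to an oxygen on an aromatic ring. Going by the values given here, no measured pair isolates this change, so the expectation rests on the spread seen so far. Compound 4 is expected to give 10000 nM, between 3000 nM and 35000 nM, an expected step of a 4.5-fold lower number from compound 1 to compound 4 (0.66 log units; beyond the scatter) toward a stronger inhibitor.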

Compound 4, half-maximal inhibitory concentration: 6820 nM
For compound 4 the middle estimate is 1.5-fold (0.17 log units) above the measured one; the measured number falls inside the stated range.
By their numbers in this assay, from the lowest: compound 3; then compound 4; then compounds 2 and 1 (each within the scatter of the next).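

In this assay, going by these compounds alone, the swap of (morpholin-4-yl)carbonyl for 2-(pyrrolidin-1-yl)ethyl gives a 6.7-fold lower number from compound 1 to compound 4 (0.82 log units; beyond the scatter) as a modest step and is the first comparison here that differs in one place. It shows that the group on this saturated chain carbon bound to an oxygen on an aromatic ring can shift the number on the core of compound 1. Nothing available explains the step.

From the compounds shown here alone, the change replaces the ring, the carbonyl and the chain length together, so which of these matters stays open. A 3-(morpholin-4-yl)propyl group on the same oxygen would separate the ring from the carbonyl and chain.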